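Working notes: from compound 3 to compound 4

The source may hold more compounds than are shown below. What is called first, only, known or untested is meant among the compounds shown, and "the series" means these compounds.

compound 1 `CC(C)n1cc(-c2cc(C(O)(C(F)(F)F)C(F)(F)F)cnc2N2CCN(S(=O)(=O)c3ccc(N)nc3)CC2)cn1`: 38 mL.min-1.g-1
compound 2 `Cc1csc(-c2cc(C(O)(C(F)(F)F)C(F)(F)F)cnc2N2CCN(S(=O)(=O)c3ccc(N)nc3)CC2)c1`: 29 mL.min-1.g-1
compound 3 `CS(=O)(=O)Nc1cccc(-c2cc(C(O)(C(F)(F)F)C(F)(F)F)cnc2N2CCN(S(=O)(=O)c3ccc(N)nc3)CC2)c1`: 40 mL.min-1.g-1

All three values come from an ADME assay (liver) for metabolic stability, with Liver microsome (Homo sapiens) as the target, using microsomes and NADPH, with a stated time of 30 min, tested at 1 uM; a higher number here means faster removal of the compound, a lower number slower removal. At 40 mL.min-1.g-1, compound 3 cannot be told apart from the other two compounds, as a 1.1-fold higher number from compound 1 to compound 3 (0.02 log units; within the scatter) and a 1.4-fold higher number from compound 2 to compound 3 (0.14 log units; within the scatter) show.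

Compound 4 `NC(=O)c1cccc(-c2cc(C(O)(C(F)(F)F)C(F)(F)F)cnc2N2CCN(S(=O)(=O)c3ccc(N)nc3)CC2)c1` carries carbamoyl in place of methanesulfonamido on an aromatic carbon, meta to a large group (carbamoyl in place of methanesulfonamido on an aromatic carbon).

Among the measured compounds shown here, no measured pair makes this exact exchange. The closest evidence comes from exchanges of the whole group at the same place on the shared core. Besides the two steps above, these include a 1.3-fold lower number from compound 1 to compound 2 (0.12 log units; within the scatter). All three steps stay small, although the groups exchanged differ widely, so no step beyond the scatter is expected in this assay. For the measured compounds named here, with only three compounds, this remains weak support.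

The expected change is a 1.2-fold lower number from compound 3 to compound 4 (0.07 log units; within the scatter), with its direction left open by the data. For compound 4, the estimated value is 34 mL.min-1.g-1, with an expected range of 20 mL.min-1.g-1 to 55 mL.min-1.g-1.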

Compound 4, intrinsic clearance in microsomes: 17 mL.min-1.g-1
Estimate against measurement, compound 4: 2.0-fold (0.30 log units) above; measured number outside the range, below it.
By their numbers in this assay, from the lowest: compounds 4, 2, 1 and 3 (each within the scatter of the next, the first and the last beyond it).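

Among compounds 1, 2 and 3, exchanges at this position gave no step beyond the scatter in this assay, whereas carbamoyl gives a 2.4-fold lower number from compound 3 to compound 4 (0.37 log units; beyond the scatter) and a 2.2-fold lower number from compound 1 to compound 4 (0.35 log units; beyond the scatter) while a 1.7-fold lower number from compound 2 to compound 4 (0.23 log units; within the scatter) remains the exception. The number can therefore move with the group at this aromatic carbon, but both steps beyond the scatter are modest and compound 4 does not separate from compound 2. The data shown contain no measurement that accounts for this step.

As far as these compounds go, it remains open whether a nitrile or a carboxylic acid on the same aromatic carbon would stand with compound 4 or with compound 3. Also open, from the compounds shown here alone, is whether a methyl group on the carbamoyl nitrogen would keep the number of compound 4 in this assay.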